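Swapping the Ring Group on the Shared Core

The source may report more compounds than this note shows. Statements on the series, on what has been measured and on what is new or still open speak of the compounds shown alone.

Compound 1 `Fc1ccc(C2=NN(C3=NC(c4ccccc4)CS3)C(c3ccc4ccccc4c3)C2)cc1` gives 9730 nM in a functional assay on HeLa cells (Homo sapiens) for inhibition, read by CCK-8 assay, with a stated time of 48 h; on this read-out lower numbers stand for stronger inhibition and higher numbers for weaker inhibition.
Compound 2 `c1ccc(C2=NN(C3=NC(c4ccccc4)CS3)C(c3ccc4ccccc4c3)C2)cc1` gives 3860 nM in this assay.
Compound 3 `O=C1CSC(N2N=C(c3ccc(Cl)cc3)CC2c2ccc3ccccc3c2)=N1` gives 6320 nM in this assay.

Among these three numbers, compound 3 stands second highest: its number lies within the scatter of that of compound 1 and also within the scatter of that of compound 2, so compound 3 cannot be ordered against either of them. Compound 4 `Clc1ccc(C2=NN(C3=NC(c4ccccc4)CS3)C(c3ccc4ccccc4c3)C2)cc1` differs from compound 3 in one place: a group of 11 heavy atoms (9 carbon, 1 nitrogen, 1 sulfur; one five-membered non-aromatic ring with 2 hetero atoms, one six-membered aromatic ring of carbon only) in place of a group of 6 heavy atoms (3 carbon, 1 nitrogen, 1 oxygen, 1 sulfur; one five-membered non-aromatic ring with 2 hetero atoms), on an amine nitrogen in a ring. Among the measured compounds shown here, no measured pair differs in exactly this way, so no measured step bears on it directly. For the measured compounds named here, the only measured step, a 2.5-fold lower number from compound 1 to compound 2 (0.40 log units; beyond the scatter), concerns a different position and shows only that the set varies modestly around a common range. Compounds 1 and 2 carry the group that enters in compound 4, and their numbers bracket that of compound 3. Compound 4 is therefore expected to stay close to compound 3, with a 1.1-fold lower number from compound 3 to compound 4 (0.06 log units; within the scatter) as the estimated step, no change beyond the scatter being foreseen. The estimate for compound 4 in this assay is 5500 nM, within a range from 2200 nM to 14000 nM.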

Compound 4, half-maximal inhibitory concentration: 7560 nM
For compound 4 the middle estimate is 1.4-fold (0.14 log units) below the measured one; the measured number falls inside the stated range.
By their numbers in this assay, from the lowest: compounds 2, 3, 4 and 1 (each within the scatter of the next, the first and the last beyond it).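

In this assay, the group of 11 heavy atoms in place of the group of 6 heavy atoms, on an amine nitrogen in a ring, gives a 1.2-fold higher number from compound 3 to compound 4 (0.08 log units; within the scatter), so this exchange, which brings in a six-membered aromatic ring of carbon only, leaves the read-out within the scatter. On the aromatic carbon, the chloro step from hydrogen gives a 2.0-fold higher number from compound 2 to compound 4 (0.29 log units; within the scatter) and the chloro step from fluoro gives a 1.3-fold lower number from compound 1 to compound 4 (0.11 log units; within the scatter); both lie within the scatter, so the chloro compound cannot be ordered against either neighbour. No evidence is at hand that would account for these results.

The compounds shown leave open whether a methoxy group or an amine on that aromatic carbon would give a step beyond the scatter. Also open, as far as these compounds go, is whether a carboxylic acid on the group at the ring nitrogen would do so.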